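Trimethylphenyl for ethoxyphenyl on a triazole nitrogen

A few compounds are considered here, and "the series" means these few. Any claim that something is new, unique, unknown or untested is made for them only; others in the source may bear on it.

Compound 2 `CCOc1ccc(-n2nncc2CN2C(=O)C3(C(C#N)=C(N)Oc4c(N)cc5nc6ccccc6nc5c43)c3ccccc32)cc1` was tested in a functional assay on HepG2 cells (Homo sapiens) for antiproliferative activity, read by MTT assay, with a stated time of 48 h; on this read-out higher numbers stand for weaker inhibition and lower numbers for stronger inhibition. In this assay compound 2 gives > 50000 nM, which is a limit of the assay and not a number. Compound 1 `N#CC1=C(N)Oc2c(c3nc4ccccc4nc3c3ccccc23)C12C(=O)N(Cc1cnnn1-c1ccc(N)cc1)c1ccccc12` gives > 50000 nM, likewise a limit. Compound 1 and compound 2 together mark (the limit of > 50000 nM in this assay, at which 2 of the 2 values shown sit). Compound 3 `Cc1cc(C)c(-n2nncc2CN2C(=O)C3(C(C#N)=C(N)Oc4c(N)cc5nc6ccccc6nc5c43)c3ccccc32)c(C)c1` differs from compound 2 by 2,4,6-trimethylphenyl in place of 4-ethoxyphenyl on an aromatic nitrogen. For the measured compounds named here, no measured step is available, so the expected step is a step that the limit leaves unreadable from compound 2 to compound 3, none beyond the scatter. For compound 3 the estimate is 60000 nM, in a range from 20000 nM to 200000 nM, and a limit is again expected as the most likely report.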

Compound 3, half-maximal inhibitory concentration: 48100 nM
For compound 3 the middle estimate is 1.2-fold (0.10 log units) above the measured one, within the range that was stated.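

For the compounds shown here, with 2,4,6-trimethylphenyl in place of 4-ethoxyphenyl on an aromatic nitrogen, compound 3 gives 48100 nM in this assay, the only value shown here that is a number and not a limit. The change reads as an at least 1.0-fold lower number from compound 2 to compound 3 (0.01 log units; that floor lies within the scatter), so the compounds show no gain from it. The true size of the step stays unknown because the comparison rests on a limit: the limit of > 50000 nM in this assay, at which 2 of the 3 values shown sit.

As far as these compounds go, it remains open whether an amine or a carboxylic acid on this phenyl ring, or a longer alkoxy chain in place of ethoxy, would give a step beyond the scatter.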